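A few compounds are considered here, and "the series" means these few. Any claim that something is new, unique, unknown or untested is made for them only; others in the source may bear on it.

Measured so far in a functional assay on HT-29 cells (Homo sapiens) for inhibition, with a stated time of 72 h; a higher number here means a weaker inhibitor, a lower number a stronger inhibitor:
compound 1 `COc1cc(C(=O)c2ccc3[nH]ccc3c2)cc(OC)c1OC`: 100 nM
compound 2 `COc1cc(C(=O)c2cccc3c2ccn3C)cc(OC)c1OC`: 22.4 nM

Compound 1 stands at the higher of the two half-maximal inhibitory concentrations; compound 2 sits at a lower number, and the gap between the two lies beyond the usual scatter. The two compounds differ in more than one place, so no single change can be read from that gap.

Compound 3 `COc1cc(C(=O)c2ccc3c(ccn3CCC(=O)O)c2)cc(OC)c1OC` has not yet been measured in this assay. It differs from compound 1 by 2-carboxyethyl in place of hydrogen on an aromatic nitrogen. Within the data shown here, no measured pair shows this change, so the expectation rests on the change itself and on where compound 1 stands. For compound 3 a move to a higher number than compound 1, beyond the scatter, is expected; the step is estimated as a 4.0-fold higher number from compound 1 to compound 3 (0.60 log units; beyond the scatter). The value expected for compound 3 is 400 nM, with a range from 80 nM to 2000 nM.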

Compound 3, half-maximal inhibitory concentration: > 10000 nM
Compound 3: no number, only a limit; the forecaster's own chance of this, stated with the estimate: 10%; middle value at least 25-fold (1.39 log units) from the limit.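

In this assay compound 3 gives > 10000 nM, which is a limit of the assay and not a number. The aromatic nitrogen of the core of compound 1 is now shown to be a place where one change, 2-carboxyethyl in place of hydrogen, carries a large cost: an at least 100-fold higher number from compound 1 to compound 3 (2.00 log units; beyond the scatter), a step that compound 1 and compound 2 alone could not show. The true size of that step stays unread, and the only figure for it comes from a limit: the limit of > 10000 nM in this assay, at which 1 of the 3 values shown sits.

The compounds shown leave open whether the loss follows the carboxylic acid or the chain itself. A methyl ester, a primary amide, an amine on the same chain, or a plain propyl group at this nitrogen would separate the two.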